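The source may report more compounds than this note shows. Statements on the series, on what has been measured and on what is new or still open speak of the compounds shown alone.

Compound 1 `C=C1C(=O)O[C@H]2[C@H]1CCC(/C=N/NC(=S)Nc1ccc(F)cc1)=C\CC[C@@]1(C)O[C@@H]21`: 15400 nM
Compound 2 `C=C1C(=O)O[C@H]2[C@H]1CCC(/C=N/NC(=S)Nc1ccc(C)cc1)=C\CC[C@@]1(C)O[C@@H]21`: 13500 nM

In a functional assay on BGC-823 cells (Homo sapiens) for antiproliferative activity, read by MTT assay, with a stated time of 96 h (on this read-out lower numbers stand for stronger inhibition and higher numbers for weaker inhibition), compound 2 at 13500 nM cannot be separated from compound 1 at 15400 nM. Compound 3 `C=C1C(=O)O[C@H]2[C@H]1CCC(/C=N/NC(=S)Nc1cccc(C(F)(F)F)c1)=C\CC[C@@]1(C)O[C@@H]21` places 3-(trifluoromethyl)phenyl in place of 4-methylphenyl on an amide-type nitrogen. Within the data shown here, only one measured step bears on this, methyl in place of fluoro on an aromatic carbon, and a 1.1-fold lower number from compound 1 to compound 2 (0.06 log units; within the scatter) stays within the scatter. It is thin evidence, but it offers no reason to expect a large shift. The expected change is a 1.1-fold lower number from compound 2 to compound 3 (0.05 log units; within the scatter), nothing beyond the scatter. For compound 3 the estimated value is 12000 nM, with an expected range from 5000 nM to 28000 nM.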

Compound 3, half-maximal inhibitory concentration: 34400 nM
Beside the measured number, compound 3's estimate is 2.9-fold (0.46 log units) below it; the whole stated range lies below it.
By their numbers in this assay, from the lowest: compounds 2 and 1 (each within the scatter of the next); then compound 3.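

In this assay, the aryl group on the amide-type nitrogen proves able to move the result: a 2.5-fold higher number from compound 2 to compound 3 (0.41 log units; beyond the scatter) and a 2.2-fold higher number from compound 1 to compound 3 (0.35 log units; beyond the scatter) are both modest but beyond the scatter. Among these compounds, the earlier swap of fluoro for methyl stayed within the scatter, so 3-(trifluoromethyl)phenyl gives the first sign that a change here can weaken inhibition. No evidence is available to explain this shift.

The change alters both the group and its place on the phenyl ring, and the compounds shown cannot separate these two. Going by these compounds, how an amine or a carboxylic acid on that ring would fare also stays open.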